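A few compounds are considered here, and "the series" means these few. Any claim that something is new, unique, unknown or untested is made for them only; others in the source may bear on it.

Among the compounds with values here, in a functional assay on SK-N-SH cells (Homo sapiens) for inhibition, read by MTT assay, with a stated time of 72 h, tested at 30 uM (a lower number here means less inhibition of growth, a higher number more inhibition of growth at the concentration tested), compound 1 (`C=CCc1cc(O)c(O)c(CN2CCC(C)CC2)c1`) gives 74.7%, the highest of the three numbers measured so far. Compound 2 (`C=CCc1ccc(OCc2cn(-c3ccc(OC)cc3)nn2)c(O)c1`) gives 31.5% and compound 3 (`C=CCc1ccc(OCc2cn(-c3cccc(C#N)c3)nn2)c(O)c1`) gives 21.2%, and both gaps to compound 1 lie beyond the scatter. Compound 4 (`C=CCc1cc(O)c(O)c(CN2CCC(Cc3ccccc3)CC2)c1`) keeps the core of compound 1 and differs in one place: phenyl in place of hydrogen on a saturated chain carbon bound to a saturated ring carbon. Cut one bond further out, the same difference reads methyl to benzyl. Within the data shown here, the only measured step between two close relatives is a number 10.3 percentage points lower from compound 2 to compound 3 (beyond the scatter), with 3-cyanophenyl in place of 4-methoxyphenyl on an aromatic nitrogen. That step is modest, but it concerns another place and another pair of compounds, so it offers only weak guidance here. Among the measured compounds shown here, no measured pair tests the change itself, so no direction can be favoured and a step within the scatter is the most reasonable expectation, held with a wide margin. The expected change is a number 1.3 percentage points higher from compound 1 to compound 4 (within the scatter). Compound 4 is estimated at 76%, with an expected range from 55% to 92%.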

Compound 4, percent growth inhibition at one concentration: 78.8%
Estimate against measurement, compound 4: 2.8 percentage points below; the measured number falls inside the stated range.
By their numbers in this assay, from the lowest: compound 3; then compound 2; then compounds 1 and 4 (each within the scatter of the next).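

In this assay, swapping methyl for benzyl gives a number 4.1 percentage points higher from compound 1 to compound 4 (within the scatter). This place, a saturated chain carbon bound to a saturated ring carbon, therefore accepts a phenyl of 6 heavy atoms with no loss of growth inhibition at the concentration tested, which the earlier step, made at another place on another pair of compounds, could not show. No measured information is available to explain this result.

From the compounds shown here alone, it remains open whether this tolerance extends to other groups at the same place, such as a longer chain like phenethyl, a benzyl carrying a carboxylic acid, or a simple amine. One step with one aromatic ring also cannot show how far a group here can grow, or whether a change here could ever move the number beyond the scatter.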